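The compounds below may be only part of what the source reports. "The series", "measured", "known", "first", "only" and "open" are said of these compounds alone.

Three compounds have been measured in an ADME assay for solubility; on this read-out lower numbers stand for lower solubility and higher numbers for higher solubility:

Compound 1 `CCCCCCCCCCCCCCCCSCC(COP(=O)(O)OP(=O)(O)OC[C@H]1OC(n2ccc(N)nc2=O)[C@@H](O)[C@@H]1O)OC(=O)CCCCCCCCCCCCCCC` gives 200000 nM.
Compound 2 `CCCCCCCCCCCCCCCCSCC(COP(=O)(O)OP(=O)(O)OC[C@H]1OC(n2ccc(N)nc2=O)[C@@H](O)[C@@H]1O)OC(=O)CCCCCCCCCCC` gives > 64000000 nM, which is a limit of the assay and not a number.
Compound 3 `CCCCCCCCCCCCCCCCCC(=O)OC(COP(=O)(O)OP(=O)(O)OC[C@H]1OC(n2ccc(N)nc2=O)[C@@H](O)[C@@H]1O)CSCCCCCCCCCCCCCCCC` gives 200000 nM.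

Compound 3 differs from compound 1 by ethyl in place of hydrogen on a saturated chain carbon, ten or more bonds along the chain from a carbonyl carbon, and the step is no change at the digits printed from compound 1 to compound 3 (within the scatter). Compound 4 `CCCCCCCCCCCCCCCCCCSCC(COP(=O)(O)OP(=O)(O)OC[C@H]1OC(n2ccc(N)nc2=O)[C@@H](O)[C@@H]1O)OC(=O)CCCCCCCCCCC` has not yet been measured; it differs from compound 2 by ethyl in place of hydrogen on a saturated chain carbon, ten or more bonds along the chain from a sulfur. This is the same kind of change, though the places as counted from the two structures are not described in the same words. The two cores differ by hydrogen in place of butyl on a saturated chain carbon, ten or more bonds along the chain from a carbonyl carbon, and that step is an at least 320-fold higher number from compound 1 to compound 2 (2.50 log units; beyond the scatter). Compound 2 sits at the limit of > 64000000 nM in this assay, at which 1 of the 3 values shown sits. Resting on the earlier ethyl step no change at the digits printed from compound 1 to compound 3 (within the scatter), the step from compound 2 to compound 4 is expected to be small, about an at least 2.1-fold lower number from compound 2 to compound 4 (0.32 log units; beyond the scatter). Compound 4 is therefore estimated at 30000000 nM, between 2000000 nM and 150000000 nM.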

Compound 4, solubility: > 54000000 nM
Compound 4 ended at the assay's limit (the forecaster's own chance of this, stated with the estimate: 45%); middle value at least 1.8-fold (0.25 log units) away from the limit.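

In this assay compound 4 gives > 54000000 nM, which is a limit of the assay and not a number. Compound 2 also gives a limit, > 64000000 nM. Going by these compounds alone, no step between compound 2 and compound 4 can be read. The compounds shown leave open whether ethyl in place of hydrogen at this place changes the read-out on the core of compound 2.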